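Swapping chloro for bromo on a second pyridine core

This account rests on a few compounds, and the source may have more. Where it says the series, first, only, none or still open, it means among the compounds named here.

Four small bases share an azetidine linked through an oxygen to a pyridine ring, and differ only in a single halogen and in where that halogen and the ether sit on the ring. Compound 1 `Clc1ncccc1OC[C@@H]1CCN1` is the reference, and in an assay on brain for binding affinity to Neuronal acetylcholine receptor; alpha4/beta2 (Rattus norvegicus) (on this read-out lower numbers stand for stronger inhibition and higher numbers for weaker inhibition), compound 1 gives 0.0084 nM. Compound 2 `Brc1ncccc1OC[C@@H]1CCN1` carries a bromine where compound 1 carries a chlorine, and in this assay compound 2 gives 0.24 nM. That one change, (bromo in place of chloro on an aromatic carbon), produced a 29-fold higher number from compound 1 to compound 2 (1.46 log units; beyond the scatter), so the bromo analogue binds far more weakly than the chloro parent.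

Compound 3 `Clc1cncc(OC[C@@H]2CCN2)c1` has the same atoms as compound 1 joined in a different arrangement; the difference between the two cores is not broken down here. In this assay compound 3 gives 0.03 nM, which stands between the other two measured numbers.

Compound 4 `Brc1cncc(OC[C@@H]2CCN2)c1` has not yet been measured. It relates to compound 3 as compound 2 relates to compound 1: the change is bromo in place of chloro on an aromatic carbon. It is the same kind of change, not the same one, since in the first pair the halogen sits next to the ring nitrogen and ortho to a group of 6 heavy atoms, whereas here it sits two atoms from the ring nitrogen and meta to a group of 6 heavy atoms. Resting only on the large loss seen in a 29-fold higher number from compound 1 to compound 2 (1.46 log units; beyond the scatter), and allowing for the different surroundings, the step from compound 3 to compound 4 is expected to be a weakening of about a 5.0-fold higher number from compound 3 to compound 4 (0.70 log units; beyond the scatter). On that basis compound 4 is estimated to give about 0.15 nM, most likely between 0.03 nM and 0.8 nM.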

Compound 4, inhibition constant: 0.021 nM
Compound 4: middle estimate off by 7.1-fold (0.85 log units), on the high side, outside the stated range (below it).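

On the core of compound 3, putting bromo in place of chloro gives a 1.4-fold lower number from compound 3 to compound 4 (0.15 log units; within the scatter), so in this assay the values of this pair cannot be told apart, even though the same swap cost a great deal of binding on the core of compound 1. The size of this swap therefore did not carry from one core to the other, and the two steps differ by more than repeat measurements would explain: the same change on two cores in this assay, a 29-fold higher number (1.46 log units; beyond the scatter) from compound 1 to compound 2 and a 1.4-fold lower number (0.15 log units; within the scatter) from compound 3 to compound 4, 41-fold (1.61 log units) apart, beyond the scatter of two such steps. This does not show why the cores respond so differently, since they differ in where both the halogen and the ether sit on the ring, and a single pair on each core cannot separate those two differences or show how any other swap would behave.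

On these data alone, whether a fluoro, a methyl or a nitrile group on the same aromatic carbon would track the chloro and bromo compounds on either core stays open. As far as these compounds go, both pairs also rest on this assay alone, so it remains unknown whether the same split between the cores would appear on any other read-out or on a third core.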